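Quinoline-Triazole Cytotoxicity: From a Decyl Chain to 4-Fluorophenyl

The source may report more compounds than this note shows. Statements on the series, on what has been measured and on what is new or still open speak of the compounds shown alone.

Compound 1, `CCCCCCCCCCn1cc(-c2nc3ccccc3cc2CCCCC)nn1`: > 100 ug/mL in a functional assay on COLO 205 cells (Homo sapiens) for cytotoxicity, read by MTT assay, with a stated time of 24 h; a higher number here means a weaker inhibitor, a lower number a stronger inhibitor
Compound 2, `CCCCCCCCCCn1cc(-c2nc3ccccc3cc2CCCC)nn1`: > 100 ug/mL
Compound 3, `CCCCc1cc2ccccc2nc1-c1cn(CCC(F)(F)C(F)(F)C(F)(F)C(F)(F)C(F)(F)C(F)(F)C(F)(F)C(F)(F)F)nn1`: > 100 ug/mL

Compound 1 reaches only the limit of the assay, (the limit of > 100 ug/mL in this assay, at which 3 of the 3 values shown sit). Compound 2 sits at that same limit, so the step that the two limits leave unreadable from compound 1 to compound 2 cannot be read. Compound 3 also stands at the limit. Compound 4, `CCCCCc1cc2ccccc2nc1-c1cn(-c2ccc(F)cc2)nn1`, carries the change (4-fluorophenyl in place of decyl on an aromatic nitrogen). Among the measured compounds shown here, no measured step bears directly on this change, and every measured compound sits at the limit. Compound 4 is therefore expected to stand near that limit, the step that the limit leaves unreadable from compound 1 to compound 4 being an estimate rather than a reading. Compound 4 is estimated at 150 ug/mL, within 40 ug/mL to 600 ug/mL.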

Compound 4, half-maximal inhibitory concentration: > 100 ug/mL
Compound 4 ended at the assay's limit; the forecaster's own chance of this, stated with the estimate: 70%; the middle value does not contradict the limit.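

No step can be read between compound 1 and compound 4, because both stand at a limit and not at a number: the limit of > 100 ug/mL in this assay, at which 4 of the 4 values shown sit.

The compounds shown leave open whether 4-fluorophenyl in place of decyl changes cytotoxicity at all, and how far any compound lies past that limit.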